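From a Trifluoromethyl Urea to a Hydroxyphenyl Extension

The source may hold more compounds than are shown below. What is called first, only, known or untested is meant among the compounds shown, and "the series" means these compounds.

Going by the values given here, in a functional assay on MIA PaCa-2 cells (Homo sapiens) for inhibition, read by MTT assay, with a stated time of 72 h (on this read-out higher numbers stand for weaker inhibition and lower numbers for stronger inhibition), compound 3 (`COc1cc(NC(C)CCCNC(=O)Nc2ccc(C(F)(F)F)cc2)c2ncccc2c1`) gives 8400 nM, the lowest of three numbers so far; compound 1 (`COc1cc(NC(C)CCCNC(=O)Nc2ccc(Br)cc2)c2ncccc2c1`) gives 23000 nM. Compound 4 (`COc1cc(NC(C)CCCNC(=O)NNC(=O)Nc2ccc(O)cc2)c2ncccc2c1`) differs from compound 3 by ((4-hydroxyphenyl)carbamoyl)amino in place of 4-(trifluoromethyl)phenyl on an amide-type nitrogen. Among the compounds with values here, the one measured single-place step, a 2.7-fold lower number from compound 1 to compound 3 (0.44 log units; beyond the scatter), is modest and concerns only the group on the aromatic carbon. Compound 4 shares the longer urea-bearing chain with the nearest guide, compound 2 (`COc1cc(NC(C)CCCNC(=O)NNC(=O)Nc2ccc(C(F)(F)F)cc2)c2ncccc2c1`), which gives 19000 nM, a higher number than compound 3 gives. A modest rise is therefore expected, a 2.4-fold higher number from compound 3 to compound 4 (0.38 log units; beyond the scatter). Compound 4 is estimated at 20000 nM, with an expected range of 9000 nM to 45000 nM.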

Compound 4, half-maximal inhibitory concentration: 142000 nM
Compound 4: the middle estimate sits 7.1-fold (0.85 log units) below what was measured; the whole stated range lies below it.
By their numbers in this assay, from the lowest: compound 3; then compounds 2 and 1 (each within the scatter of the next); then compound 4.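

Read in this assay, hydroxy in place of trifluoromethyl on an aromatic carbon gives the only single-place reading of this change (a 7.5-fold higher number from compound 2 to compound 4 (0.87 log units; beyond the scatter)). The whole ((4-hydroxyphenyl)carbamoyl)amino group gives a larger step in place of 4-(trifluoromethyl)phenyl (a 17-fold higher number from compound 3 to compound 4 (1.23 log units; beyond the scatter)) and a further one in place of 4-bromophenyl (a 6.2-fold higher number from compound 1 to compound 4 (0.79 log units; beyond the scatter)). Compound 4 thus has the highest number of the four, so the aromatic substituent matters more here than the bromo-to-trifluoromethyl change suggested. From the compounds shown here alone, whether a methoxy or an amine on that aromatic carbon would follow hydroxy, and how hydroxy behaves on the urea of compound 3, stays open. No evidence on hand speaks to the reason for this result.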